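From compound 3 to compound 4: a ring gives way to a chain

The source may hold more compounds than are shown below. What is called first, only, known or untested is meant among the compounds shown, and "the series" means these compounds.

Measured so far:
Compound 1 `N#Cc1c(O)nc(SCc2nc3ccccc3[nH]2)nc1-c1ccccc1`: 4.63 nM
Compound 2 `N#Cc1c(Nc2ccccc2)nc(SCc2nc3ccccc3[nH]2)nc1-c1ccccc1`: 3.2 nM
Compound 3 `N#Cc1c(Nc2nccs2)nc(SCc2nc3ccccc3[nH]2)nc1-c1ccccc1`: 14.7 nM

All three values come from a functional assay on K562 cells (Homo sapiens) for cytotoxicity, read by MTT assay, with a stated time of 3 days; a lower number here means a stronger inhibitor, a higher number a weaker inhibitor. Among them, compound 3 has the highest number and so is the weakest inhibitor of the three. The modest 3.2-fold higher number from compound 1 to compound 3 (0.50 log units; beyond the scatter) and the similarly modest a 4.6-fold higher number from compound 2 to compound 3 (0.66 log units; beyond the scatter) both show this. By contrast, a 1.4-fold lower number from compound 1 to compound 2 (0.16 log units; within the scatter) does not separate the other two compounds.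

The next compound is compound 4 `N#Cc1c(NNC(N)=S)nc(SCc2nc3ccccc3[nH]2)nc1-c1ccccc1`, which has not yet been measured. The structural change is a group of 4 heavy atoms (1 carbon, 2 nitrogen, 1 sulfur; no ring) in place of a group of 5 heavy atoms (3 carbon, 1 nitrogen, 1 sulfur; one five-membered aromatic ring with 2 hetero atoms), on a nitrogen on an aromatic ring. It lies on a nitrogen on an aromatic ring, where the 1,3-thiazol-2-yl group leaves and a group with no ring enters.

The three measured steps all concern this part of the molecule, and none is large. None of them, however, tests an open chain, so they offer only a loose guide. Since compound 3 sits at the high end of a narrow range, a small move back into that range seems most likely. The expected change in this assay is a 1.8-fold lower number from compound 3 to compound 4 (0.26 log units; within the scatter). Compound 4 is estimated at 8 nM, with an expected range from 2.5 nM to 25 nM.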

Compound 4, half-maximal inhibitory concentration: 8.9 nM
Estimate against measurement, compound 4: 1.1-fold (0.05 log units) below, within the range that was stated.
By their numbers in this assay, from the lowest: compounds 2, 1, 4 and 3 (each within the scatter of the next, the first and the last beyond it).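

In this assay, a group with no ring can stand on this nitrogen on an aromatic ring: replacing the 1,3-thiazol-2-yl group with the open chain gives a 1.7-fold lower number from compound 3 to compound 4 (0.22 log units; within the scatter), so a ring at this position is not required for a value of this size. Compared with the phenyl group at the same place, the chain gives a 2.8-fold higher number from compound 2 to compound 4 (0.44 log units; beyond the scatter), a modest but real gap, while replacing the hydroxy group on the aromatic carbon with the whole nitrogen-linked chain gives a 1.9-fold higher number from compound 1 to compound 4 (0.28 log units; within the scatter), so the chain can be told apart only from the phenyl compound. Nothing available explains these differences.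

On these data alone, the chain changes several things at once, so it remains open which part of it matters: a plain amino group, a hydrazine with nothing further on it, or the same chain with oxygen in place of sulfur could each separate these parts. Also open, as far as these compounds go, is how a saturated ring such as cyclohexyl on this nitrogen would compare with the aromatic rings and the open chain.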